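This account rests on a few compounds, and the source may have more. Where it says the series, first, only, none or still open, it means among the compounds named here.

Measured so far:
Compound 1 `O=C(/C=C/c1cccc(F)c1)N1CCC=CS1(=O)=O`: in a functional assay on HeLa cells (Homo sapiens) for inhibition, read by sulforhodamine B assay, with a stated time of 48 h (a higher number here means a weaker inhibitor of growth, a lower number a stronger inhibitor of growth), compound 1 gives < 100 nM, which is a limit of the assay rather than a number.
Compound 2 `O=C(/C=C/c1cccc(C(F)(F)F)c1)N1CCC=CS1(=O)=O`: in this assay compound 2 gives 19600 nM.

Compound 2 thus holds the only number shown; the other value is a limit. Compound 3 `Cc1cccc(/C=C/C(=O)N2CCC=CS2(=O)=O)c1` differs from compound 2 by methyl in place of trifluoromethyl on an aromatic carbon. For the measured compounds named here, the one measured step at this position, an at least 190-fold higher number from compound 1 to compound 2 (2.29 log units; beyond the scatter), was large, and the limit of < 100 nM in this assay, at which 1 of the 2 values shown sits, makes its size a floor. The move to methyl is therefore expected to lower the number, by a 9.8-fold lower number from compound 2 to compound 3 (0.99 log units; beyond the scatter). Compound 3 is expected to give 2000 nM, within 200 nM to 20000 nM.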

Compound 3, concentration for 50% growth inhibition: 20700 nM
Compound 3: the middle estimate sits 10-fold (1.01 log units) below what was measured; the whole stated range lies below it.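

Trifluoromethyl and methyl cannot be told apart at this position, with a 1.1-fold higher number from compound 2 to compound 3 (0.02 log units; within the scatter). Methyl in place of fluoro gives an at least 200-fold higher number from compound 1 to compound 3 (2.31 log units; beyond the scatter), so among these three compounds the large gap separates fluoro from both other groups. The value of compound 1 is a limit, which makes the size of that step a floor: the limit of < 100 nM in this assay, at which 1 of the 3 values shown sits.

On these data alone, what remains open is whether fluoro is a lone exception at this position. A chlorine atom, a methoxy group or an amine in its place could read like compound 1, like compound 3, or differently from both.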